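Swapping dimethylamino for chloro on the aromatic ring

The source may hold more compounds than are shown below. What is called first, only, known or untested is meant among the compounds shown, and "the series" means these compounds.

Compound 2 `CC1=CC[C@H](C(C)(C)NC(=S)N/N=C/c2ccc(N(C)C)cc2)CC1` was tested in a functional assay on PC-3 cells (Homo sapiens) for inhibition, read by sulforhodamine B assay, with a stated time of 48 h (on this read-out higher numbers stand for weaker inhibition of growth and lower numbers for stronger inhibition of growth), and there compound 2 gives < 40 nM, which is a limit of the assay rather than a number. Compound 1 `COc1ccc(/C=N/NC(=S)NC(C)(C)[C@H]2CC=C(C)CC2)cc1` in this assay likewise gives < 40 nM, also a limit. The step that the two limits leave unreadable from compound 1 to compound 2 therefore tells nothing, as the limit of < 40 nM in this assay, at which 2 of the 2 values shown sit, shows. Compound 3 `CC1=CC[C@H](C(C)(C)NC(=S)N/N=C/c2ccc(Cl)cc2)CC1` differs from compound 2 by chloro in place of dimethylamino on an aromatic carbon. Among the measured compounds shown here, no measured step covers such a change, so the expectation rests on the limit alone. The estimated step that the limit leaves unreadable from compound 2 to compound 3 is expected to stay within the scatter. Compound 3 is estimated at 30 nM, ranging from 8 nM to 120 nM.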

Compound 3, concentration for 50% growth inhibition: 50 nM
Compound 3: the middle estimate sits 1.7-fold (0.22 log units) below what was measured; the measured number falls inside the stated range.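

In this assay, chloro gives this position its first reading that is a number and not a limit, so the change can now be bounded on one side. The comparison shows an at least 1.2-fold higher number from compound 2 to compound 3 (0.09 log units; that floor lies within the scatter), and likewise an at least 1.2-fold higher number from compound 1 to compound 3 (0.09 log units; that floor lies within the scatter). Neither floor establishes a real difference, and the full size of each step cannot be read, because compound 1 and compound 2 each sit at a limit: the limit of < 40 nM in this assay, at which 2 of the 3 values shown sit. From the compounds shown here alone, what a nitro group or a carboxylic acid would give on this aromatic carbon stays open.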